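The compounds below may be only part of what the source reports. "The series", "measured", "known", "first", "only" and "open" are said of these compounds alone.

Compound 1 `O=C(Nc1cccc(-n2cc(-c3ccncc3)c(-c3ccc(Cl)c(O)c3)n2)c1)Nc1cc(C(F)(F)F)cc(C(F)(F)F)c1` gives 739 nM in a functional assay on MDA-MB-231 cells (Homo sapiens) for inhibition, read by sulforhodamine B assay, with a stated time of 48 h; a lower number here means a stronger inhibitor of growth, a higher number a weaker inhibitor of growth. Compound 2 `COc1cc(-c2nn(-c3cccc(NC(=O)Nc4cccc(C(F)(F)F)c4)c3)cc2-c2ccncc2)ccc1Cl` gives 811 nM. Compound 3 `COc1cc(-c2nn(-c3cccc(NC(=O)Nc4ccc(Cl)c(C(F)(F)F)c4)c3)cc2-c2ccncc2)ccc1Cl` gives 760 nM.

Among these three, compound 2 carries the highest number, yet it is separated from compound 3 by a 1.1-fold lower number from compound 2 to compound 3 (0.03 log units; within the scatter) and from compound 1 by a gap that is likewise within the scatter, so no order among them can be read. The unmeasured compound 4 `COc1cc(-c2nn(-c3cccc(NC(=O)Nc4cc(C(F)(F)F)cc(C(F)(F)F)c4)c3)cc2-c2ccncc2)ccc1Cl` arises from compound 2 by a single change: trifluoromethyl in place of hydrogen on an aromatic carbon.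

Among the compounds with values here, only one measured step touches the same ring, the one from compound 2 to compound 3, where chloro replaces hydrogen on an aromatic carbon, and it was a 1.1-fold lower number from compound 2 to compound 3 (0.03 log units; within the scatter). Compound 1 already carries the same bis-trifluoromethyl ring on a different partner ring, and its value sits within the scatter of compound 2. Nothing here points to a step beyond the scatter, so compound 4 is expected to give about 750 nM, with a likely range of 400 nM to 1400 nM. That estimate means a step of a 1.1-fold lower number from compound 2 to compound 4 (0.03 log units; within the scatter), expected to stay within the usual scatter.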

Compound 4, concentration for 50% growth inhibition: 664 nM
Estimate against measurement, compound 4: 1.1-fold (0.05 log units) above, and the stated range covers the measured number.
By their numbers in this assay, from the lowest: compounds 4, 1, 3 and 2 (each within the scatter of the next).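

In this assay, the new trifluoromethyl group on the six-membered aromatic ring of carbon only, meta to a trifluoromethyl group, leaves compound 4 within the scatter of compound 2 (a 1.2-fold lower number from compound 2 to compound 4 (0.09 log units; within the scatter)). Within the data shown here, this position therefore takes the four added heavy atoms without a readable effect on the number, as the earlier compounds could suggest only indirectly. With this ring now the same in both compounds, the methyl on the oxygen also gives no readable difference (a 1.1-fold lower number from compound 1 to compound 4 (0.05 log units; within the scatter)), which compound 1 alone could not show.

As far as these compounds go, whether an amine or a carboxylic acid at this position would move the number beyond the scatter remains open. Nothing available explains why these values lie so close together.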